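A few compounds are considered here, and "the series" means these few. Any claim that something is new, unique, unknown or untested is made for them only; others in the source may bear on it.

In an assay on isolated protein for inhibition of protein kinase C zeta type (Homo sapiens), read by mobility shift assay, tested at 30 uM (on this read-out higher numbers stand for more inhibition at the one concentration tested (going by the name of the read-out) and lower numbers for less inhibition), compound 1 `COC(=O)CCc1c(C)[nH]c(=O)c2c(N)nn(C)c12` gives 14%. Compound 2 `CC(C)(C)c1cc2nn(-c3ccccc3)c(N)c2c(=O)[nH]1` in this assay gives -1%, the lowest of the two numbers; compound 1 sits above it by a gap beyond the scatter. Compound 3 `COc1ccc(-c2cc3nn(-c4ccccc4)c(N)c3c(=O)[nH]2)cc1` carries one change relative to compound 2: 4-methoxyphenyl in place of tert-butyl on an aromatic carbon. Within the data shown here, no measured pair shows this exchange, so its size is not fixed by the data. A small step is expected, a number 6 percentage points higher from compound 2 to compound 3 (within the scatter), probably not beyond the scatter. On that basis compound 3 is estimated in this assay at 5%, in a range of -10% to 25%.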

Compound 3, a percentage reported as inhibition, at one concentration (the size of the read-out at that concentration, not a potency): 0%
For compound 3 the middle estimate is 5 percentage points above the measured one; the range from low to high includes it.
By their numbers in this assay, from the lowest: compounds 2 and 3 (each within the scatter of the next); then compound 1.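

In this assay, 4-methoxyphenyl in place of tert-butyl on the aromatic carbon next to the ring nitrogen comes to a number 1 percentage points higher from compound 2 to compound 3 (within the scatter). This position therefore carries either group, with or without an aromatic ring and a hydrogen-bond acceptor, and the read-out does not separate them. No measurement at hand offers an explanation for this.

On these data alone, whether an amine or a carboxylic acid on this carbon would shift the number remains open. Compound 1 differs from compound 2 and compound 3 in more than one place, so it does not settle this.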